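Removing One Methoxy Group: From Compound 3 to Compound 4

A few compounds are considered here, and "the series" means these few. Any claim that something is new, unique, unknown or untested is made for them only; others in the source may bear on it.

Of the compounds shown here, three have been measured. In a functional assay on Hs-578T cells (Homo sapiens) for inhibition, read by sulforhodamine B assay, with a stated time of 48 h (a lower number here means that less compound is tolerated, a higher number that more compound is tolerated), compound 1 (`COc1cc(-c2cc(/C=C/C(=O)c3ccc(N)cc3)[nH]n2)cc(OC)c1OC`) gives > 100000 nM, which is a limit of the assay and not a number. Compound 2 (`COc1cc(-c2cc(/C=C/C(=O)c3ccc(Cl)c(Cl)c3)[nH]n2)cc(OC)c1OC`) gives > 100000 nM, again a limit. Compound 3 (`COc1ccc(C(=O)/C=C/c2cc(-c3cc(OC)c(OC)c(OC)c3)n[nH]2)cc1OC`) gives > 100000 nM, also a limit.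

Compound 3 therefore stands where the other two stand: at the limit of > 100000 nM in this assay, at which 3 of the 3 values shown sit. The changes among the measured compounds on the carbonyl carbon give a step that the two limits leave unreadable from compound 1 to compound 2, a step that the two limits leave unreadable from compound 1 to compound 3 and a step that the two limits leave unreadable from compound 2 to compound 3, so none of them offers a readable size.

Compound 4 (`COc1ccc(C(=O)/C=C/c2cc(-c3cc(OC)c(OC)c(OC)c3)n[nH]2)cc1`) differs from compound 3 by hydrogen in place of methoxy on an aromatic carbon. Within the data shown here, no measured step touches this position, and the three measured values give no direction or size to build on. Compound 4 is expected to remain at the limit, a step of a number no higher from compound 3 to compound 4 (the limit leaves the size open) being estimated. The estimate for compound 4 is 100000 nM, within 30000 nM to 300000 nM, with the limit itself being the most likely outcome.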

Compound 4, concentration lethal to 50% of the cells: > 100000 nM
Compound 4 ended at the assay's limit; the forecaster's own chance of this, stated with the estimate: 75%; the middle value sits exactly at the limit.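

Compound 4 stands at a limit of the assay, as do compound 1, compound 2 and compound 3, so no step among these compounds can be read: the limit of > 100000 nM in this assay, at which 4 of the 4 values shown sit.

The compounds shown leave open where each true value lies and whether any of these changes alters it.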